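Swapping pyridinyl for nitrophenyl on a shared core

The source may hold more compounds than are shown below. What is called first, only, known or untested is meant among the compounds shown, and "the series" means these compounds.

Compound 1 `O[C@@H](c1ccccc1)[C@H]1CO[C@H](c2ccccc2)[C@@H](C/C=C/c2ccccn2)C1` is one of three measured compounds. In a functional assay on HeLa cells (Homo sapiens) for cytotoxicity, read by WST assay, with a stated time of 48 h (on this read-out lower numbers stand for stronger inhibition and higher numbers for weaker inhibition), compound 1 gives 33800 nM, the second highest of the three numbers. Compound 2 `COc1ccc([C@H]2OC[C@H]([C@@H](O)c3ccc(OC)c(OC)c3)C[C@@H]2C/C=C/c2ccc(OC)c(OC)c2)cc1` gives 46700 nM and compound 3 `COc1ccc(/C=C/C[C@H]2C[C@@H]([C@@H](O)c3ccc(OC)c(OC)c3)CO[C@@H]2c2ccc(OC)c(OC)c2)cc1OC` gives 23800 nM; both sit within the scatter of compound 1. Within the data shown here, the one single-point step among the measured compounds, a 2.0-fold lower number from compound 2 to compound 3 (0.29 log units; within the scatter), changes a methoxy group on an aromatic carbon and stays within the scatter.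

Compound 4 `O=[N+]([O-])c1ccccc1/C=C/C[C@H]1C[C@@H]([C@@H](O)c2ccccc2)CO[C@@H]1c1ccccc1` differs from compound 1 by 2-nitrophenyl in place of pyridin-2-yl on a double-bonded chain carbon bound to a double-bonded chain carbon. Among the measured compounds shown here, no measured step involves this kind of aryl exchange, and the single measured step was within the scatter, so no change beyond the scatter is expected. Compound 4 is therefore expected to give about 30000 nM, with a likely range from 10000 nM to 90000 nM. That amounts to an expected step of a 1.1-fold lower number from compound 1 to compound 4 (0.05 log units; within the scatter).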

Compound 4, half-maximal inhibitory concentration: 11800 nM
Compound 4: the middle estimate sits 2.5-fold (0.41 log units) above what was measured, and the stated range covers the measured number.
By their numbers in this assay, from the lowest: compounds 4, 3, 1 and 2 (each within the scatter of the next, the first and the last beyond it).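

In this assay, 2-nitrophenyl in place of pyridin-2-yl on the double-bonded chain carbon gives a 2.9-fold lower number from compound 1 to compound 4 (0.46 log units; beyond the scatter), a modest step but the first among these compounds to lie beyond the scatter. The number therefore responds to the aryl group at this position, which the methoxy step, within the scatter, could not show. Nothing measured here explains the shift. The compounds shown leave open whether the nitro group or the loss of the ring nitrogen carries this step. An unsubstituted phenyl or a 2-aminophenyl at the same place would help separate the two.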